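Testing a Methoxy Change on a Second Core

This account rests on a few compounds, and the source may have more. Where it says the series, first, only, none or still open, it means among the compounds named here.

Compound 1 `COc1ccc(-c2c(C#N)c(N)c(C#N)c(SC)c2-c2ccccc2)cc1` and compound 2 `COc1ccc(-c2c(C#N)c(N)c(C#N)c(SC)c2-c2ccc(OC)cc2)cc1` share one core and differ only by methoxy in place of hydrogen on an aromatic carbon. In an assay on isolated protein for inhibition of glucose-6-phosphatase catalytic subunit 1 (Homo sapiens), tested at 100 uM (on this read-out higher numbers stand for more inhibition at the one concentration tested (going by the name of the read-out) and lower numbers for less inhibition), compound 1 gives 6.8%, and compound 2 gives 5.5%; the resulting step is a number 1.3 percentage points lower from compound 1 to compound 2 (within the scatter). Compound 3 `Cc1c(-c2ccccc2)c(C#N)c(N)c(C#N)c1N1CCCCC1` is built on a different core, and how its core differs from that of compound 1 is not broken down here. In this assay compound 3 gives 38.2%, the highest of the three numbers, beyond the scatter from both others. Compound 4 `COc1ccc(-c2c(C)c(N3CCCCC3)c(C#N)c(N)c2C#N)cc1` has not yet been measured; it differs from compound 3 by methoxy in place of hydrogen on an aromatic carbon, the same change seen between compound 1 and compound 2, at the same place. The expected step is a number 2.2 percentage points lower from compound 3 to compound 4 (within the scatter), and this expectation rests on a number 1.3 percentage points lower from compound 1 to compound 2 (within the scatter), a single pair on another core. Compound 4 is therefore estimated at 36%, with a likely range from 22% to 50%.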

Compound 4, a percentage reported as inhibition, at one concentration (the size of the read-out at that concentration, not a potency): 33.3%
Compound 4: the middle estimate sits 2.7 percentage points above what was measured; the range from low to high includes it.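

In this assay, the change from phenyl to 4-methoxyphenyl comes with a number 4.9 percentage points lower from compound 3 to compound 4 (within the scatter). Set beside the earlier pair, the change reads alike on the two cores: the same change on two cores in this assay, a number 1.3 percentage points lower (within the scatter) from compound 1 to compound 2 and a number 4.9 percentage points lower (within the scatter) from compound 3 to compound 4, 3.6 percentage points apart, within the scatter of two such steps. Among the compounds shown here, this shows that methoxy in place of hydrogen makes no readable difference on either core, but with only two pairs, both within the scatter, it does not show that a larger effect would carry across cores or that other changes would carry across in the same way.

The compounds shown leave open whether a different group in the same place, such as an amine, a carboxylic acid or a longer chain, would shift the number beyond the scatter. They also leave open whether such a shift would then be the same on both cores.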